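The source may report more compounds than this note shows. Statements on the series, on what has been measured and on what is new or still open speak of the compounds shown alone.

Three compounds built around a shared aryl sulfonate tail were tested in an assay on HEK293 cells for antagonist activity at P2X purinoceptor 7 (Homo sapiens), read by fluorescence, with a stated time of 2 h; on this read-out lower numbers stand for stronger inhibition and higher numbers for weaker inhibition. Compound 1, `CS(=O)(=O)c1ccc(C(=O)N2CCC(n3cncc3-c3ccc(OS(=O)(=O)c4cccc5cnccc45)cc3)CC2)cc1`, gives 25 nM. Compound 2, `O=C(c1ccc([N+](=O)[O-])cc1)N1CCC(n2cncc2-c2ccc(OS(=O)(=O)c3cccc4cnccc34)cc2)CC1`, differs from compound 1 only by nitro in place of methylsulfonyl on an aromatic carbon, and compound 2 gives 1.49 nM. That single swap produced a 17-fold lower number from compound 1 to compound 2 (1.22 log units; beyond the scatter), a clear gain in inhibition.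

Compound 3, `CS(=O)(=O)c1ccc(C(=O)N2CCC(c3nc4cc(OS(=O)(=O)c5cccc6cnccc56)ccc4[nH]3)CC2)cc1`, carries the same methylsulfonyl-bearing amide on a different core; the difference between the two cores is not broken down here. Compound 3 gives 7 nM, between the other two measured values.

Compound 4, `O=C(c1ccc([N+](=O)[O-])cc1)N1CCC(c2nc3cc(OS(=O)(=O)c4cccc5cnccc45)ccc3[nH]2)CC1`, is made from compound 3 by nitro in place of methylsulfonyl on an aromatic carbon, the same change that separates compound 1 from compound 2, at the same place. Among the compounds with values here, because the earlier swap gave a 17-fold lower number from compound 1 to compound 2 (1.22 log units; beyond the scatter), a step of the same direction is expected here, and the step from compound 3 to compound 4 is estimated as a 10-fold lower number from compound 3 to compound 4 (1.00 log units; beyond the scatter), a little more cautious than the first since only one example is known. Compound 4 is therefore expected to come in around 0.7 nM, with a likely range from 0.25 nM to 2.5 nM.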

Compound 4, half-maximal inhibitory concentration: 13 nM
The estimate for compound 4 lay 19-fold (1.27 log units) below the measured number; measured number above the stated range.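

In this assay, putting nitro in place of methylsulfonyl gives a 1.9-fold higher number from compound 3 to compound 4 (0.27 log units; within the scatter), so on this core the swap produces no difference that can be told apart from the ordinary spread of repeat measurements. The large gain seen on the core of compound 1 therefore did not carry over to the core of compound 3, and the two steps genuinely differ: the same change on two cores in this assay, a 17-fold lower number (1.22 log units; beyond the scatter) from compound 1 to compound 2 and a 1.9-fold higher number (0.27 log units; within the scatter) from compound 3 to compound 4, 31-fold (1.49 log units) apart, beyond the scatter of two such steps

This shows that, in these two pairs, the result of the swap depends on the core it is made on, so a step measured on one core is not a safe forecast for the other; it does not show why the cores differ, or what the swap would do on any third core.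

The compounds shown carry only methylsulfonyl and nitro at this place, so it remains open how an amine, a carboxylic acid or a nitrile there would behave on either core. Also open, going by these compounds, is whether the two cores would part in the same way for a change made elsewhere, such as on the sulfonate tail.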